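A few compounds are considered here, and "the series" means these few. Any claim that something is new, unique, unknown or untested is made for them only; others in the source may bear on it.

Working notes on the series. Compound 1 `O=C(CN(c1ncnc2c1ncn2C1CCCCO1)C1CC1)N[C@@H](CC(=O)OCc1ccccc1)C(=O)OCc1ccccc1` and compound 2 `CC(C)(C)OC(=O)NCCCC[C@H](NC(=O)CN(c1ncnc2c1ncn2C1CCCCO1)C1CC1)C(=O)OCc1ccccc1` share the same core and are measured in a functional assay on the whole organism (Tail, strain ICR) with Mus musculus as the target, in the tail flick test, with a stated time of 150 min, at a dose of 25 umol/kg by the oral route; a lower number here means a weaker effect, a higher number a stronger effect of the compound at the dose given. In this assay compound 1 gives 0.06%, while compound 2 gives 17.2%. Going by the values given here, the one change between them, 3-((tert-butoxycarbonyl)amino)propyl in place of benzyloxycarbonyl on a saturated chain carbon, two bonds along the chain from an amide-type nitrogen and a carbonyl carbon, produces a number 17.1 percentage points higher from compound 1 to compound 2 (beyond the scatter). Among the compounds with values here, compound 2 therefore stands highest of the two numbers measured, with compound 1 as its only neighbour, lower and beyond the scatter.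

Compound 3 `N=C(N)NCCC[C@H](NC(=O)CN(c1ncnc2c1ncn2C1CCCCO1)C1CC1)C(=O)OCc1ccccc1` is not yet measured. It differs from compound 2 by a group of 4 heavy atoms (1 carbon, 3 nitrogen; no ring) in place of a group of 9 heavy atoms (6 carbon, 1 nitrogen, 2 oxygen; no ring), on a saturated chain carbon, four bonds along the chain from an amide-type nitrogen and a carbonyl carbon, on a saturated chain carbon, four bonds along the chain from an amide-type nitrogen and a carbonyl carbon. Within the data shown here, no measured step alters this same side chain in this manner; the single step from compound 1 to compound 2 changes a different position and gives no guidance on the size or direction here. For compound 3 the expected outcome in this assay is therefore set close to the measured value of compound 2, with wide bounds: compound 3 is estimated at 13% (range 0% to 35%). The expected step from compound 2 to compound 3 is a number 4.2 percentage points lower from compound 2 to compound 3 (within the scatter), within the scatter.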

Compound 3, a percentage reported as activity, at one dose (the size of the read-out at that dose, not a potency): 19.6%
For compound 3 the middle estimate is 6.6 percentage points below the measured one, and the stated range covers the measured number.
By their numbers in this assay, from the lowest: compound 1; then compounds 2 and 3 (each within the scatter of the next).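

In this assay, the group of 4 heavy atoms (1 carbon, 3 nitrogen) in place of ((tert-butoxycarbonyl)amino)methyl, on a saturated chain carbon, four bonds along the chain from an amide-type nitrogen and a carbonyl carbon, gives a number 2.4 percentage points higher from compound 2 to compound 3 (within the scatter), so two end groups with different counts of heavy atoms, hydrogen-bond donors and acceptors cannot be told apart at this position. The comparison with the aspartate-type side chain, a number 19.5 percentage points higher from compound 1 to compound 3 (beyond the scatter), gives a second step beyond the scatter alongside a number 17.1 percentage points higher from compound 1 to compound 2 (beyond the scatter), and within the three compounds it is compound 1 that stands apart, while compound 2 and compound 3 stay within the scatter of each other. Nothing measured here accounts for either the lack of separation or the distance from compound 1.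

The compounds shown leave open whether a plain primary amine at the chain end, a carboxylic acid in place of the benzyl ester, or a longer chain would keep, raise or lose the read-out in this assay. They also leave open whether the similar read-outs of compound 2 and compound 3 would hold at other doses or times.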